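Adding one methyl to compound 3

The source may report more compounds than this note shows. Statements on the series, on what has been measured and on what is new or still open speak of the compounds shown alone.

In a functional assay on MT4 cells (Homo sapiens) for cytotoxicity (a lower number here means that less compound is tolerated, a higher number that more compound is tolerated), compound 1 (`O=c1cc(Cc2c(F)cccc2F)nc(SC2CCCC2)[nH]1`) gives > 200000 nM as a limit of the assay and not a number. Compound 2 (`CCC(C)Sc1nc(O)cc(C(CC)c2ccccc2)n1`) likewise gives > 200000 nM as a limit. Compound 1 and compound 2 therefore share the limit of > 200000 nM in this assay, at which 2 of the 3 values shown sit, and have no exact reading. Among the compounds with values here, compound 3 (`CC(C)Sc1nc(O)cc(C(C)c2cccc3ccccc23)n1`) stands alone with 119000 nM as the only exact reading in this assay so far. On these data alone, the true values of the other two are unknown, so its distance from them stays open.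

Compound 4 (`CCC(c1cc(O)nc(SC(C)C)n1)c1cccc2ccccc12`) alters compound 3 in one place, with methyl in place of hydrogen on a saturated chain carbon, two bonds along the chain from two aromatic carbons as the difference: methyl in place of hydrogen on a saturated chain carbon, two bonds along the chain from two aromatic carbons. Cut one bond further out, the same difference reads methyl to ethyl.

Within the data shown here, no measured pair in this small set shows what such a change does, so the expectation is modest: no step beyond the usual scatter, in either direction. It starts from compound 3 at 119000 nM as the nearest measured reference. The expected step is a 1.1-fold higher number from compound 3 to compound 4 (0.02 log units; within the scatter) and it remains an estimate. In this assay compound 4 is estimated at 125000 nM with 50000 nM to 200000 nM as the expected range.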

Compound 4, half-maximal cytotoxic concentration: 16900 nM
Compound 4: the middle estimate sits 7.4-fold (0.87 log units) above what was measured, and the stated range ends above it.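

Within the data shown here, this is the first pair here that differs in one place and has an exact reading on both sides, so it gives the first direct look at this position. In this assay, methyl in place of hydrogen on a saturated chain carbon, two bonds along the chain from two aromatic carbons, gives a 7.0-fold lower number from compound 3 to compound 4 (0.85 log units; beyond the scatter), so less compound is tolerated once the extra carbon is present. A single added carbon, turning methyl into ethyl at this position, is therefore enough to move the cytotoxicity reading beyond the usual scatter, although this one pair cannot say why.

On these data alone, it remains open whether the number would keep falling with a longer chain such as propyl, or how an amine on the same carbon would read. Compound 1 and compound 2 cannot settle this, since each differs from compound 4 in more than one place and neither has an exact reading: the limit of > 200000 nM in this assay, at which 2 of the 4 values shown sit.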